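The source may report more compounds than this note shows. Statements on the series, on what has been measured and on what is new or still open speak of the compounds shown alone.

Three compounds on a shared core have been run in a functional assay on HOS-TE85 cells (Homo sapiens) for inhibition, read by CCK-8 assay, with a stated time of 72 h, tested at 1 uM; on this read-out higher numbers stand for more inhibition at the one concentration tested (going by the name of the read-out) and lower numbers for less inhibition. In this assay compound 1 `COc1ccc(C)cc1N1C(=O)CSC1c1cccc(C(=O)NCCCCc2ccccc2)c1` gives 95%, compound 2 `COc1cc(F)ccc1N1C(=O)CSC1c1cccc(C(=O)NCCCCc2ccccc2)c1` gives 94%, and compound 3 `Cc1cccc(N2C(=O)CSC2c2cccc(C(=O)NCCCCc3ccccc3)c2)c1` gives 96%. On these numbers compound 3 stands with the largest of the three, but the standing means little: the step of a number 1 percentage points higher from compound 1 to compound 3 (within the scatter) and the step of a number 2 percentage points higher from compound 2 to compound 3 (within the scatter) are both within the scatter, as is the step of a number 1 percentage points lower from compound 1 to compound 2 (within the scatter), so the three are not told apart by this read-out.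

The next compound, compound 4 `COc1ccc(N2C(=O)CSC2c2cccc(C(=O)NCCCCc3ccccc3)c2)c(OC)c1`, differs from compound 3 in one place: 2,4-dimethoxyphenyl in place of 3-methylphenyl on an amide-type nitrogen in a ring. Two of the measured steps bear on this change. The step of a number 1 percentage points higher from compound 1 to compound 3 (within the scatter) removed a methoxy from the aryl ring on the ring nitrogen without effect beyond the scatter, and the step of a number 2 percentage points higher from compound 2 to compound 3 (within the scatter) exchanged one substituted aryl on that nitrogen for another, again within the scatter. Every variation of this aryl so far has left the read-out unchanged, so no step beyond the scatter is expected from compound 3 to compound 4, that is a number 2 percentage points lower from compound 3 to compound 4 (within the scatter). Compound 4 is therefore estimated to give 94% in this assay, in a range from 85% to 99%.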

Compound 4, a percentage reported as inhibition, at one concentration (the size of the read-out at that concentration, not a potency): 58%
The estimate for compound 4 lay 36 percentage points above the measured number; measured number outside the range, below it.
By their numbers in this assay, from the lowest: compound 4; then compounds 2, 1 and 3 (each within the scatter of the next).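

The aryl group on the amide-type nitrogen is less free to vary than compounds 1 to 3 suggested: in this assay the change to 2,4-dimethoxyphenyl brings a number 38 percentage points lower from compound 3 to compound 4 (beyond the scatter) when it replaces 3-methylphenyl and a number 37 percentage points lower from compound 1 to compound 4 (beyond the scatter) when it replaces 2-methoxy-5-methylphenyl. The narrowest comparison is a number 36 percentage points lower from compound 2 to compound 4 (beyond the scatter) where methoxy takes the place of fluoro on an aromatic carbon, so a single exchange on an aryl that already carries a methoxy is enough for the loss, and compounds 1 and 2 show that one methoxy on this aryl does not bring it by itself. Nothing available explains this loss.

The compounds shown leave open whether the drop belongs to this second methoxy in particular or would follow from other groups in its place, such as a hydroxyl, an ethoxy or a dimethylamino group. They also leave open whether a 4-methoxyphenyl without the 2-methoxy would keep the high read-out of compound 3 or fall with compound 4.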